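This account rests on a few compounds, and the source may have more. Where it says the series, first, only, none or still open, it means among the compounds named here.

Working notes on the series, read-out a physicochemical assay for solubility, using the shake flask method, in phosphate buffer, measured as kinetic solubility, with a stated time of 20 h, at pH 6.5; on this read-out lower numbers stand for lower solubility and higher numbers for higher solubility. Compound 1 (`FC(F)(F)c1cccc(-c2nc3cnc(Nc4ncccn4)cc3[nH]2)c1`) reads < 5000 nM, which is a limit of the assay and not a number. Among the measured compounds shown here, compound 2 (`FC1(F)CCC(c2nc3cnc(Nc4ccc(C(F)(F)F)cn4)cc3[nH]2)C1`) gives 120000 nM, the only true number so far in this assay, so it is the sole numerical anchor for what follows. Compound 3 (`FC(F)(F)c1ccc(Nc2cc3[nH]c(C4CC4)nc3cn2)nc1`) keeps the rest of compound 2 and carries cyclopropyl in place of 3,3-difluorocyclopentyl on an aromatic carbon. For the measured compounds named here, no measured pair isolates a single change, so the step size rests on judgement alone. A modest fall, only a little beyond the usual scatter, is expected, and the estimated step is a 2.4-fold lower number from compound 2 to compound 3 (0.38 log units; beyond the scatter). The uncertainty is wide and a reading at the assay limit cannot be excluded. For compound 3 the expected value is 50000 nM, with an estimated range of 10000 nM to 180000 nM.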

Compound 3, solubility: < 5000 nM
Compound 3: a limit, no number (the forecaster's own chance of this, stated with the estimate: 20%); at least 10-fold (1.00 log units) between middle value and limit.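

Among the compounds shown here, this is the first step that changes one place only, and it shows that the aromatic carbon between two ring nitrogen atoms strongly affects the read-out in this assay: cyclopropyl in place of 3,3-difluorocyclopentyl gives an at least 24-fold lower number from compound 2 to compound 3 (1.38 log units; beyond the scatter). Compound 3 stands at a limit of the assay and not at a number, so the step has a lower bound on its size but no end point. Its full size cannot be read, because the value of compound 3 lies at the assay limit: the limit of < 5000 nM in this assay, at which 2 of the 3 values shown sit.

The compounds shown do not separate the change in ring size from the loss of the two fluorine atoms. Also open, on these data alone, is how this position responds to a plain cyclopentyl or to a group carrying an amine.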